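The source may hold more compounds than are shown below. What is called first, only, known or untested is meant among the compounds shown, and "the series" means these compounds.

Two members of this series have numbers. Compound 1 `C[C@H](NC(=O)CN(c1nc(Cl)nc2[nH]cnc12)C1CC1)C(=O)OCc1ccccc1` in a functional assay on the whole organism (Tail, strain ICR) with Mus musculus as the target, in the tail flick test, with a stated time of 30 min, at a dose of 25 umol/kg by the oral route (on this read-out higher numbers stand for a stronger effect at the one dose given and lower numbers for a weaker effect), gives 41.2%. Compound 2 `CC[C@H](C)[C@H](NC(=O)CN(c1ncnc2c1ncn2C1CCCCO1)C1CC1)C(=O)OCc1ccccc1` gives 25.6% in this assay; this is the lowest of the two numbers, and the nearest, compound 1, stands higher by a gap beyond the usual scatter. Among the compounds with values here, no pair differing in one place has been measured, so no single step size is known from the data.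

Compound 3 `CC(C)(C)OC(=O)NCCCC[C@H](NC(=O)CN(c1ncnc2c1ncn2C1CCCCO1)C1CC1)C(=O)OCc1ccccc1` has not yet been measured in this assay. It differs from compound 2 by 4-((tert-butoxycarbonyl)amino)butyl in place of sec-butyl on a saturated chain carbon bound to an amide-type nitrogen and a carbonyl carbon.

Within the data shown here, with no measured step of this kind to lean on, the expected change is small: the step of a number 2.6 percentage points lower from compound 2 to compound 3 (within the scatter) is estimated to stay within the scatter, with the range left wide on both sides. Compound 3 is therefore expected to read about 23% in this assay, within 5% to 45%.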

Compound 3, a percentage reported as activity, at one dose (the size of the read-out at that dose, not a potency): 18.3%
Compound 3: the middle estimate sits 4.7 percentage points above what was measured; the measured number falls inside the stated range.
By their numbers in this assay, from the lowest: compounds 3 and 2 (each within the scatter of the next); then compound 1.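

In this assay, within the data shown here, the step of a number 7.3 percentage points lower from compound 2 to compound 3 (within the scatter) is the first reading of a single change, with 4-((tert-butoxycarbonyl)amino)butyl in place of sec-butyl on a saturated chain carbon bound to an amide-type nitrogen and a carbonyl carbon. At this position, a much larger chain carrying nitrogen, oxygen and a hydrogen-bond donor therefore does not separate compound 3 from compound 2 beyond the scatter. No measurement offers an explanation for this result.

On these data alone, it remains open whether a free amine at the end of the butyl chain, a carboxylic acid or a phenyl ring at this position would move the read-out beyond the scatter. Compound 1 differs from compound 2 in more than one place, so the gap between them cannot be assigned to any single change.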